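Ring-opened amine replaces aminocyclohexyl on the shared core

A few compounds are considered here, and "the series" means these few. Any claim that something is new, unique, unknown or untested is made for them only; others in the source may bear on it.

Three compounds of this series have numbers in an assay on HeLa cells for inhibition of sphingosine-1-phosphate transporter SPNS2 (Mus musculus), read by LC-MS, tested at 2 uM; on this read-out lower numbers stand for less inhibition and higher numbers for more inhibition at the one concentration tested (going by the name of the read-out). Compound 1 `CCCCCCCCCCc1ccc(-c2noc([C@@H]3CCNC3)n2)cc1` gives 62% in this assay. Compound 2 `CCCCCCCCCCc1ccc(-c2noc([C@@H]3CC[C@H](N)C3)n2)cc1` gives 38%. Compound 3 `CCCCCCCCCCc1ccc(-c2noc([C@@H]3CCC[C@@H](N)C3)n2)cc1` gives 13%, the lowest of the three; the steps to it are a number 49 percentage points lower from compound 1 to compound 3 (beyond the scatter) and a number 25 percentage points lower from compound 2 to compound 3 (beyond the scatter), and between the other two a number 24 percentage points lower from compound 1 to compound 2 (beyond the scatter).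

Compound 4 `CCCCCCCCCCc1ccc(-c2noc(C(Cl)CCN)n2)cc1` carries the change (a group of 5 heavy atoms (3 carbon, 1 nitrogen, 1 chlorine; no ring) in place of a group of 7 heavy atoms (6 carbon, 1 nitrogen; one six-membered non-aromatic ring of carbon only), on an aromatic carbon). For the measured compounds named here, none of the measured steps covers a group without a ring, so the bearing of the earlier steps is indirect: within the measured set, widening the ring from pyrrolidin-3-yl to 3-aminocyclopentyl to 3-aminocyclohexyl went with falling inhibition, and the group entering in compound 4 is the smaller of the two, closer in count to the group of compound 1. A rise back toward the middle of the measured range is therefore expected, but with wide uncertainty; for compound 4 the estimated step is a number 15 percentage points higher from compound 3 to compound 4 (beyond the scatter). Compound 4 is estimated at 28%, within 8% to 50%.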

Compound 4, a percentage reported as inhibition, at one concentration (the size of the read-out at that concentration, not a potency): 5%
For compound 4 the middle estimate is 23 percentage points above the measured one; measured number outside the range, below it.
By their numbers in this assay, from the lowest: compounds 4 and 3 (each within the scatter of the next); then compound 2; then compound 1.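

In this assay, opening the ring at this position of the shared core brings no recovery of inhibition (a number 8 percentage points lower from compound 3 to compound 4 (within the scatter)), so the ring-free group with chlorine and 3-aminocyclohexyl cannot be told apart here. Heavy-atom count alone does not follow the numbers: the entering group has the same count as the group of compound 1, yet the steps are (a number 57 percentage points lower from compound 1 to compound 4 (beyond the scatter)) and (a number 33 percentage points lower from compound 2 to compound 4 (beyond the scatter)). No measured evidence bears on the reason for this result.

On these data alone, whether the low number goes with the chlorine or with the loss of the ring stays open, and a plain 3-aminopropyl group on the same core would separate the two. Also open, as far as these compounds go, is whether a piperidin-3-yl ring, with its nitrogen inside the ring as in compound 1, would read nearer compound 1 or compound 3.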